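Amino for Methyl on a Boron-Bearing Indole Series

The source may report more compounds than this note shows. Statements on the series, on what has been measured and on what is new or still open speak of the compounds shown alone.

Compound 3 `Cc1ccc(C(=O)c2ccn(-c3ccc4c(c3)B(O)OC4)c2)cc1` is one of three compounds examined in an ADME assay on L929 cells (Mus musculus) for cytotoxicity, read by resazurin assay, with a stated time of 72 h; a higher number here means a weaker inhibitor, a lower number a stronger inhibitor. In this assay compound 3 gives only a limit, > 10 ug/mL. Compound 1 `COc1ccc(S(=O)(=O)c2cn(-c3ccc4c(c3)B(O)OC4)c3ccccc23)cc1` also gives only a limit in this assay, > 10 ug/mL. Compound 2 `OB1OCc2ccc(-n3cccc3Sc3ccccc3Cl)cc21` likewise gives only a limit in this assay, > 10 ug/mL. Among the measured compounds shown here, the whole picture so far is the limit of > 10 ug/mL in this assay, at which 3 of the 3 values shown sit; no compound yet shows a number, and no step between measured compounds can be drawn. Compound 4 `Nc1ccc(C(=O)c2ccn(-c3ccc4c(c3)B(O)OC4)c2)cc1` differs from compound 3 by amino in place of methyl on an aromatic carbon. For the measured compounds named here, with no measured step to lean on, the step that the limit leaves unreadable from compound 3 to compound 4 is expected to stay within the scatter. In this assay compound 4 is therefore expected to give about 15 ug/mL, between 8 ug/mL and 40 ug/mL, most likely reported again only as a limit.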

Compound 4, half-maximal inhibitory concentration: 3.9 ug/mL
Compound 4: the middle estimate sits 3.8-fold (0.59 log units) above what was measured; the measured number lies below the stated range.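

Swapping 4-methylphenyl for 4-aminophenyl on the shared core shows that this aromatic carbon, para to a large group, is not silent in this assay: the change gives an at least 2.5-fold lower number from compound 3 to compound 4 (0.40 log units; beyond the scatter). That step is only a bound, as compound 3 gives a limit rather than a number. Compound 4 alone has moved off the limit that holds the others: the limit of > 10 ug/mL in this assay, at which 3 of the 4 values shown sit.

On these data alone, what stays open is whether this response is specific to the amino group. As far as these compounds go, a hydroxyl, a methylamino or an acetamide at the same place could settle that, and how far compound 3 truly lies from compound 4 remains unknown.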